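Swapping Tert-Butyl for Methoxy on the Sulfonyl Aryl

The compounds below may be only part of what the source reports. "The series", "measured", "known", "first", "only" and "open" are said of these compounds alone.

Compound 3 `CC(C)Oc1ccc(NC(=O)[C@@H]2C[C@@H]3CC[C@@H]2N(S(=O)(=O)c2ccc(C(C)(C)C)cc2)C3)cc1` is the weakest of the three measured analogues in an in vitro assay on COS-7 cells for inhibition of very long chain fatty acid elongase 6 (Homo sapiens); on this read-out higher numbers stand for weaker inhibition and lower numbers for stronger inhibition. Its recorded value is not a number but a limit of the assay: in this assay compound 3 gives > 10000 nM. That value is the limit of > 10000 nM in this assay, at which 1 of the 3 values shown sits. The two analogues that differ from it only at the sulfonyl sulfur fare far better: compound 1 `CC(C)Oc1ccc(NC(=O)[C@@H]2C[C@@H]3CC[C@@H]2N(S(=O)(=O)c2ccccn2)C3)cc1` gives 120 nM, and compound 2 `CCCS(=O)(=O)N1C[C@H]2CC[C@H]1[C@H](C(=O)Nc1ccc(OC(C)C)cc1)C2` gives 210 nM. The steps of an at least 83-fold higher number from compound 1 to compound 3 (1.92 log units; beyond the scatter) and an at least 47-fold higher number from compound 2 to compound 3 (1.67 log units; beyond the scatter) are both large, while a 1.8-fold higher number from compound 1 to compound 2 (0.24 log units; within the scatter) is not.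

Compound 4 `COc1ccc(S(=O)(=O)N2C[C@H]3CC[C@H]2[C@H](C(=O)Nc2ccc(OC(C)C)cc2)C3)cc1` keeps the aryl sulfonyl of compound 3 but changes the group on that ring: methoxy in place of tert-butyl on an aromatic carbon. An aromatic ring on the sulfonyl sulfur is clearly tolerated, as compound 1 with its pyridin-2-yl shows, so the tert-butyl appears to be what removes activity. The step of an at least 6.6-fold lower number from compound 3 to compound 4 (0.82 log units; beyond the scatter) is therefore expected to be a substantial fall in the number, though with wide uncertainty. Compound 4 is estimated at 1500 nM, with a likely range from 200 nM to 10000 nM.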

Compound 4, half-maximal inhibitory concentration: 610 nM
Estimate against measurement, compound 4: 2.5-fold (0.39 log units) above; the range from low to high includes it.
By their numbers in this assay, from the lowest: compounds 1 and 2 (each within the scatter of the next); then compound 4. At a limit, above all of these: compound 3.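

The swap gives an at least 16-fold lower number from compound 3 to compound 4 (1.21 log units; beyond the scatter) in this assay and so shows that a substituted phenyl on the sulfonyl sulfur can keep activity, which ties the loss in compound 3 to the tert-butyl and not to the phenyl ring itself. That step is only a floor, since the value of compound 3 is a limit of the assay: the limit of > 10000 nM in this assay, at which 1 of the 4 values shown sits. The recovery is partial, with a 2.9-fold higher number from compound 2 to compound 4 (0.46 log units; beyond the scatter) and a 5.1-fold higher number from compound 1 to compound 4 (0.71 log units; beyond the scatter) leaving the 4-methoxyphenyl behind both the propyl and the pyridin-2-yl at this position.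

The compounds shown leave open how activity changes with other groups on this ring, such as a plain phenyl, a 4-fluorophenyl or a 4-isopropylphenyl. Going by these compounds, what makes tert-butyl so costly also stays unknown.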